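Cytotoxicity notes on the thiourea and pyrimidinone series

This account rests on a few compounds, and the source may have more. Where it says the series, first, only, none or still open, it means among the compounds named here.

The series begins with compound 1 `COC(=O)C1=C(C)NC(=S)NC1c1cccs1`, which in an ADME assay on Vero cells (Chlorocebus sabaeus) for cytotoxicity, read by XTT assay, with a stated time of 72 h (on this read-out higher numbers stand for lower toxicity in this test and lower numbers for higher toxicity in this test), is recorded as "non-toxic" (no number reported), a word and no number. Compound 2 `CC1=C(C(=O)Nc2ccccc2Cl)C(c2cnc(CS)n2Nc2ccccc2)NC(=O)N1` carries a phenyl on a nitrogen on an aromatic ring. In this assay compound 2 gives > 100000 nM, which is a limit of the test and not a measured number. Compound 3 `CC1=C(C(=O)Nc2ccccc2Cl)C(c2cnc(CS)n2NCc2ccccc2)NC(=O)N1` carries a benzyl at that nitrogen instead. In this assay compound 3 gives > 100000 nM, again a limit rather than a number. The step that the two limits leave unreadable from compound 2 to compound 3 therefore cannot be read in size. Compound 3 thus stands at the same limit as compound 2, with compound 1 described only in words; the only firm point is the limit of > 100000 nM in this assay, at which 2 of the 3 values shown sit.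

Compound 4 `CCOC(=O)C1=C(C)NC(=O)NC1c1cnc(CS)n1NCc1ccccc1` differs from compound 3 by ethoxy in place of (2-chlorophenyl)amino on a carbonyl carbon. Among the compounds with values here, no measured step in this assay touches a carbonyl substituent, and the one step that exists is unreadable, so no direction beyond the scatter can be drawn from the data. Compound 4 is expected to sit at the same limit, with the step of a number no higher from compound 3 to compound 4 (the limit leaves the size open) estimated as nil. For compound 4 the estimate in this assay is 100000 nM, within the range 40000 nM to 250000 nM.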

Compound 4, half-maximal cytotoxic concentration: "non-toxic" (no number reported)
The entry for compound 4 holds no number; the estimate stays without a comparison.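

Compound 4 is recorded in this assay as "non-toxic" (no number reported), so no step can be read from compound 3 to compound 4. The compounds shown leave open at what concentration, if any, each of them becomes cytotoxic in this assay, and the only firm point remains a limit: the limit of > 100000 nM in this assay, at which 2 of the 4 values shown sit.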